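The compounds below may be only part of what the source reports. "The series", "measured", "known", "first", "only" and "open" are said of these compounds alone.

Compound 1 `O=C(O)c1ccc(C(=O)c2ccc(C(=O)c3ccc(C(=O)O)cc3)cc2)cc1`: in an assay on CHO cells for inhibition of 3-oxo-5-alpha-steroid 4-dehydrogenase 2 (Homo sapiens) (a higher number here means a weaker inhibitor, a lower number a stronger inhibitor), compound 1 gives 1000 nM. Compound 2 `O=C(O)c1ccc(C(=O)c2ccc(C(=O)c3ccc(Cl)cc3)cc2)cc1`: in this assay compound 2 gives 35 nM.

Going by the values given here, compound 2 stands lowest of the two numbers; its nearest neighbour is compound 1, and the only step measured so far runs a 29-fold lower number from compound 1 to compound 2 (1.46 log units; beyond the scatter). Compound 3 `O=C(O)c1ccc(C(=O)c2ccc(C(=O)c3ccc([N+](=O)[O-])cc3)cc2)cc1` has not yet been measured. It differs from compound 2 in one place: nitro in place of chloro on an aromatic carbon. Among the compounds with values here, no measured step exchanges chloro for nitro, so the bearing of the one known step is indirect: it shows that the group on that aromatic carbon matters strongly, yet it tells nothing about nitro itself. Compound 3 is therefore expected to lie near compound 2 in this assay, perhaps a little higher, with the step estimated as a 1.7-fold higher number from compound 2 to compound 3 (0.23 log units; within the scatter). Compound 3 is estimated at 60 nM, within a range from 20 nM to 200 nM.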

Compound 3, inhibition constant: 100 nM
Compound 3: the middle estimate sits 1.7-fold (0.22 log units) below what was measured; the range from low to high includes it.
By their numbers in this assay, from the lowest: compound 2; then compound 3; then compound 1.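

In this assay, going by these compounds alone, replacing chloro with nitro on the aromatic carbon para to a large group gives the first direct comparison between two groups other than carboxy (a 2.9-fold higher number from compound 2 to compound 3 (0.46 log units; beyond the scatter)), and it shows that this position separates even these two. Nitro also improves on carboxy (a 10-fold lower number from compound 1 to compound 3 (1.00 log units; beyond the scatter)), so the gain seen earlier is not confined to chloro, although chloro gives the lowest number of the three. Nothing given here accounts for this order.

Chloro and nitro differ in both heavy atoms and hydrogen-bond acceptors, so this single pair cannot show which of these differences, if either, tracks the change. From the compounds shown here alone, it also remains open where an amine, a methoxy group or a bromo group would fall at this position, and whether the same order would hold elsewhere on the shared core.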